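This account rests on a few compounds, and the source may have more. Where it says the series, first, only, none or still open, it means among the compounds named here.

Of the compounds shown here, three sharing one core have been tested in a functional assay on RAW264.7 cells (Mus musculus), with a stated time of 3 days; a higher number here means a weaker inhibitor, a lower number a stronger inhibitor. Compound 1 `COc1cnc(-c2ccccn2)nc1NCc1ccccc1C` gives 220 nM. Compound 2 `COc1cnc(-c2ccccn2)nc1N1CCCCCC1` gives 690 nM. Compound 3 `COc1cnc(-c2ccccn2)nc1NC(C)c1ccccc1` gives 660 nM. Among these three numbers compound 2 stands highest; its value and that of compound 3 lie within the scatter of each other, so nothing separates them, while compound 1 shows a number beyond the scatter lower than compound 2 does.

The next compound, compound 4 `COc1cnc(-c2ccccn2)nc1NCCCCO`, has not yet been measured. Set against compound 2, the change is (4-hydroxybutyl)amino in place of azepan-1-yl on an aromatic carbon. Among the compounds with values here, no measured pair shows this change, so no step between measured compounds tells what it does here.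

The expectation rests only on the three numbers given. For compound 4, the step of a 1.3-fold higher number from compound 2 to compound 4 (0.12 log units; within the scatter) is expected to be small, without a clear direction, and quite possibly no larger than the scatter. The estimate for compound 4 in this assay is 900 nM, within a range from 300 nM to 3000 nM.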

Compound 4, half-maximal inhibitory concentration: 3000 nM
Compound 4: middle estimate off by 3.3-fold (0.52 log units), on the low side, and the stated range covers the measured number.
By their numbers in this assay, from the lowest: compound 1; then compounds 3 and 2 (each within the scatter of the next); then compound 4.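

In this assay, (4-hydroxybutyl)amino in place of azepan-1-yl on this aromatic carbon gives a clear loss (a 4.3-fold higher number from compound 2 to compound 4 (0.64 log units; beyond the scatter)), so this position does not treat all amino groups alike. The second comparison keeps the chain carbon bound to the nitrogen and puts 3-hydroxypropyl in place of 2-methylphenyl, and it gives a large loss (a 14-fold higher number from compound 1 to compound 4 (1.13 log units; beyond the scatter)), which shows that the group carried on that nitrogen strongly affects the number. Nothing measured here explains either step.

The compounds shown leave open whether the hydroxyl or the open chain goes with the higher number. A plain butylamino group would separate those two, and a methoxy group at the end of the same chain would show whether the hydroxyl hydrogen matters.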